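Hydrazone series: furan-2-yl replacing 2-chloro-6-hydroxyphenyl

The compounds below may be only part of what the source reports. "The series", "measured", "known", "first", "only" and "open" are said of these compounds alone.

Measured compounds, all in a functional assay on PC-3 cells (Homo sapiens) for inhibition; on this read-out lower numbers stand for stronger inhibition and higher numbers for weaker inhibition:
- compound 1, `Cc1c(C(=O)N/N=C\c2ccccc2F)oc2cccc(O)c12`, gives >= 40000 nM, a limit of the assay.
- compound 2, `Cc1c(C(=O)N/N=C\c2cccc(F)c2)oc2cccc(O)c12`, gives >= 40000 nM, a limit of the assay.
- compound 3, `Cc1c(C(=O)N/N=C\c2c(O)cccc2Cl)oc2cccc(O)c12`, gives 18700 nM.

Among the measured compounds shown here, compound 3 holds the only number in this assay; the other two values are limits. The move from compound 1 to compound 2, a step that the two limits leave unreadable from compound 1 to compound 2, cannot be read because of the limit of >= 40000 nM in this assay, at which 2 of the 3 values shown sit. The two steps onto compound 3 are readable as lower bounds: an at least 2.1-fold lower number from compound 1 to compound 3 (0.33 log units; beyond the scatter) and an at least 2.1-fold lower number from compound 2 to compound 3 (0.33 log units; beyond the scatter), both beyond the scatter.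

Compound 4, `Cc1c(C(=O)N/N=C\c2ccco2)oc2cccc(O)c12`, is not yet measured. It differs from compound 3 by furan-2-yl in place of 2-chloro-6-hydroxyphenyl on a carbon with a double bond to nitrogen. For the measured compounds named here, the only relevant evidence is the pair of steps onto compound 3, which show that the 2-chloro-6-hydroxyphenyl group carries whatever gain the series has over the fluorophenyl analogues; taking it away and putting in the smaller furan-2-yl removes that group entirely. The expectation for compound 4 is therefore a step back toward the limit, i.e. a higher number in this assay, of about a 2.1-fold higher number from compound 3 to compound 4 (0.33 log units; beyond the scatter), with a fair chance that only a limit is reported.

Estimated value for compound 4 in this assay: 40000 nM, expected range 15000 nM to 100000 nM.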

Compound 4, half-maximal inhibitory concentration: >= 40000 nM
Compound 4: a limit, no number; the forecaster's own chance of this, stated with the estimate: 60%; the middle value lies on the limit itself.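

In this assay the change to furan-2-yl on a carbon with a double bond to nitrogen gives an at least 2.1-fold higher number from compound 3 to compound 4 (0.33 log units; beyond the scatter) and so adds a five-membered aromatic ring with 1 hetero atom to the two fluorophenyl groups as a replacement that yields no number; among the four compounds, only compound 3 with its 2-chloro-6-hydroxyphenyl group gives one. Compound 4 gives a limit of the assay and not a number, so the size of the loss on leaving compound 3 has only a lower bound. The steps from compound 1 and from compound 2 to compound 4 cannot be read, and furan-2-yl cannot be ranked against either fluorophenyl group, because all three compounds sit at the same limit: the limit of >= 40000 nM in this assay, at which 3 of the 4 values shown sit.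

Still open, from the compounds shown here alone, is whether the number for compound 3 needs both the hydroxy group and the chlorine or only one of them, which a phenyl ring carrying only the hydroxy group or only the chlorine would separate. Also open, going by these compounds, is how a phenyl ring carrying an amine or a carboxylic acid would read at this place, and how far below the limit any such group could go.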